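This account rests on a few compounds, and the source may have more. Where it says the series, first, only, none or still open, it means among the compounds named here.

Of the compounds shown here, two built on a shared core have so far been tested in a functional assay on the whole organism for inhibition, with Cavia porcellus as the target, at a dose of 1 mg/kg by the oral route; a lower number here means a weaker effect, a higher number a stronger effect of the compound at the dose given. Compound 1 `COc1ccc(-c2nc(C(C)C)sc2-c2ccc(OC)cc2)cc1` carries an isopropyl group on the five-membered ring and gives 6%. Compound 2 `COc1ccc(-c2nc(CC(N)=O)sc2-c2ccc(OC)cc2)cc1` carries a carbamoylmethyl group in the same place and gives 39%. For the measured compounds named here, compound 2 thus stands at the higher of the two numbers recorded, and the only measured step, a number 33 percentage points higher from compound 1 to compound 2 (beyond the scatter), lies beyond the scatter and is large.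

Compound 3 `COc1ccc(-c2nc(C(F)(F)F)sc2-c2ccc(OC)cc2)cc1` has not yet been measured. It differs from compound 2 in one place: trifluoromethyl in place of carbamoylmethyl on an aromatic carbon.

Going by the values given here, the single measured step bears directly on this change, since it too exchanges the carbamoylmethyl group at this position for a different group. Because a number 33 percentage points higher from compound 1 to compound 2 (beyond the scatter) was large, taking the carbamoylmethyl group away again is expected to give back most of that gain, so the expected step is a number 27 percentage points lower from compound 2 to compound 3 (beyond the scatter), a fall beyond the scatter. Compound 3 is therefore estimated at 12%, with a likely range from 0% to 30%.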

Compound 3, a percentage reported as inhibition, in the whole organism at one dose (the size of the read-out at that dose, not a potency): 83%
Compound 3: middle estimate off by 71 percentage points, on the low side; the measured number lies above the stated range.
By their numbers in this assay, from the lowest: compound 1; then compound 2; then compound 3.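

At this position on the five-membered ring, next to the ring nitrogen and the ring sulfur, the carbamoylmethyl group does not mark the top of the range in this assay: replacing it with trifluoromethyl gives a number 44 percentage points higher from compound 2 to compound 3 (beyond the scatter). The earlier pair could have suggested that the amide's hydrogen-bond donor and acceptor were what raised the number, but trifluoromethyl has 0 of each and still gives the highest number of the three, so neither is required for a strong effect in this series. Set against isopropyl, a group of a different kind, the same trifluoromethyl shows a number 77 percentage points higher from compound 1 to compound 3 (beyond the scatter), and no measurement available here explains why this one group stands so far above the other two.

Three groups cannot show whether the high number is particular to trifluoromethyl or is shared by others at this position, such as a methyl group, a chlorine atom, a nitrile or a carboxylic acid. The compounds also leave open whether the result holds if either 4-methoxyphenyl group is replaced, and the stronger effect of compound 3 is known only at the one dose tested, not at any other dose.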